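This account rests on a few compounds, and the source may have more. Where it says the series, first, only, none or still open, it means among the compounds named here.

Working notes on the series. Compound 1 `Cc1cccnc1-c1ccc(C(=O)Nc2ccc(C(C)(C)C)cc2)cc1` is the reference point. Among the measured compounds shown here, in a functional assay for antagonist activity at transient receptor potential cation channel subfamily V member 1 (Rattus norvegicus) (a higher number here means a weaker inhibitor, a lower number a stronger inhibitor), compound 1 gives 9 nM, the lowest of the three numbers so far. Compound 2 `CCCNc1cccnc1-c1ccc(C(=O)Nc2ccc(C(C)(C)C)cc2)cc1` gives 37 nM in this assay, and compound 3 `CC(C)(C)c1ccc(NC(=O)c2ccc(-c3ncccc3NS(=O)(=O)c3ccccc3)cc2)cc1` gives 166 nM. Both measured steps replace the same methyl on an aromatic carbon: a 4.1-fold higher number from compound 1 to compound 2 (0.61 log units; beyond the scatter) and an 18-fold higher number from compound 1 to compound 3 (1.27 log units; beyond the scatter); between the two replacements, a 4.5-fold higher number from compound 2 to compound 3 (0.65 log units; beyond the scatter).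

Compound 4 `CC(C)(C)c1ccc(NC(=O)c2ccc(-c3ncccc3-c3ncc[nH]3)cc2)cc1` changes the same aromatic carbon: 1H-imidazol-2-yl in place of methyl on an aromatic carbon. The steps from compound 1 to compound 2 and from compound 1 to compound 3 bear on it, and both run to a higher number, modest for propylamino and large for (phenylsulfonyl)amino. The entering 1H-imidazol-2-yl is a ring-bearing group with a donor and an acceptor where methyl had none, so a step to a higher number in this assay is expected, nearer the modest than the large one. The expected step is a 5.6-fold higher number from compound 1 to compound 4 (0.74 log units; beyond the scatter). The estimate for compound 4 is 50 nM, with a range from 15 nM to 200 nM.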

Compound 4, half-maximal inhibitory concentration: 694 nM
Beside the measured number, compound 4's estimate is 14-fold (1.14 log units) below it; measured number outside the range, above it.
By their numbers in this assay, from the lowest: compound 1; then compound 2; then compound 3; then compound 4.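

In this assay, 1H-imidazol-2-yl gives the largest step at this aromatic carbon so far, a 77-fold higher number from compound 1 to compound 4 (1.89 log units; beyond the scatter), and every replacement of methyl shown here has raised the number. It also lies beyond both replacements linked through nitrogen, with a 4.2-fold higher number from compound 3 to compound 4 (0.62 log units; beyond the scatter) and a 19-fold higher number from compound 2 to compound 4 (1.27 log units; beyond the scatter), so the series now spans a wide range at this one position, and the presence of a ring does not by itself set the order, since (phenylsulfonyl)amino also carries one and stays lower. No measurement available here accounts for this order.

The compounds shown leave open whether any replacement at this carbon can match or improve on methyl. On these data alone, whether chlorine, ethyl or methoxy would stay close to compound 1, and whether a phenyl ring would stay close to compound 4, also remains open.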